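Adding a third methoxy to a dimethoxy styryl lactone

A few compounds are considered here, and "the series" means these few. Any claim that something is new, unique, unknown or untested is made for them only; others in the source may bear on it.

Measured compounds:
compound 1 `COc1cc(/C=C/C2CC(=O)C=CO2)cc(OC)c1OC` gives 85.4 uM
compound 2 `COc1ccc(/C=C/C2CC=CC(=O)O2)cc1OC` gives 16.8 uM
compound 3 `COc1cc(/C=C/C2CC=CC(=O)O2)cc(OC)c1` gives 19.1 uM

These values come from a functional assay on OVCAR-3 cells (Homo sapiens) for inhibition, read by sulforhodamine B assay, with a stated time of 48 h; a lower number here means a stronger inhibitor of growth, a higher number a weaker inhibitor of growth. Compound 3 sits close to compound 2, within the usual scatter, while compound 1 has a clearly higher number, beyond the scatter. Compound 4 `COc1cc(/C=C/C2CC=CC(=O)O2)cc(OC)c1OC` is the next step from compound 3, and the change is methoxy in place of hydrogen on an aromatic carbon. Among the compounds with values here, no pair of measured compounds differs by this change alone, so the data give no direct guide to its size. Compound 1 also carries three methoxy groups but on a different core, so its weaker value cannot be read across. For compound 4 the expected step of a 1.3-fold lower number from compound 3 to compound 4 (0.10 log units; within the scatter) is small, and compound 4 is estimated at 15 uM, with a range from 5 uM to 50 uM.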

Compound 4, concentration for growth inhibition (reported as GI): 44.9 uM
The estimate for compound 4 lay 3.0-fold (0.48 log units) below the measured number, within the range that was stated.
By their numbers in this assay, from the lowest: compounds 2 and 3 (each within the scatter of the next); then compounds 4 and 1 (each within the scatter of the next).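

In this assay, placing methoxy on the aromatic carbon ortho to two methoxy groups and para to a group of 9 heavy atoms gives a 2.4-fold higher number from compound 3 to compound 4 (0.37 log units; beyond the scatter), so growth inhibition weakens with this change. Starting from the other dimethoxy compound, the same kind of change gives a 2.7-fold higher number from compound 2 to compound 4 (0.43 log units; beyond the scatter), in the same direction. With three methoxy groups on each, the change of core gives a 1.9-fold lower number from compound 1 to compound 4 (0.28 log units; within the scatter), so the two cores cannot be told apart here.

Nothing measured here explains these steps. On these data alone, whether a hydroxy group or a fluorine on this carbon would also weaken growth inhibition stays open.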